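This account rests on a few compounds, and the source may have more. Where it says the series, first, only, none or still open, it means among the compounds named here.

Compound 1 `Cc1cc(C)c(CN2CCc3c(Cl)cc([C@@H](CO)[C@@H]4CCCO4)c(Cl)c3C2=O)c(=O)[nH]1` was tested in a physicochemical assay for lipophilicity, at pH 7.4 (on this read-out lower numbers stand for lower lipophilicity and higher numbers for higher lipophilicity), and gives 2.1. Among the compounds that return a single number in this assay it stands higher; compound 3 `COc1cc(C)[nH]c(=O)c1CN1CCc2c(Cl)cc([C@@H](O)C3COC3)c(Cl)c2C1=O` gives 1.3, a gap that lies beyond the usual scatter of repeated measurements. Compound 2 `COC(c1cc(Cl)c2c(c1Cl)C(=O)N(Cc1c(C)cc(C)[nH]c1=O)CC2)C1CCN(C2COC2)CC1` was measured repeatedly, giving 2.7; 2.8 (2 entries), and the close agreement of these repeats is shown in the several entries of compound 2 in this assay, 2.7; 2.8 (2 entries), which gives a sense of how reproducible this assay is.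

Compound 4 `Cc1cc(C)c(CN2CCc3c(Cl)cc([C@H](CO)[C@@H]4CCCO4)c(Cl)c3C2=O)c(=O)[nH]1` has not yet been measured. Compared with compound 1 it changes as follows: the two compounds have the same atoms and bonds and differ only in configuration as drawn: 1 of 2 stereo elements differ; a stereocentre at a saturated chain carbon is drawn S in compound 1 and R in compound 4. Within the data shown here, no pair of measured compounds differing in exactly one place is available here, so there is no measured step to lean on. The expected step from compound 1 to compound 4, no change at the digits printed from compound 1 to compound 4 (within the scatter), is none beyond the scatter. Compound 4 is therefore estimated at 2.1, with a range from 1.7 to 2.5.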

Compound 4, distribution coefficient: 2.4
Beside the measured number, compound 4's estimate is 0.30 log units below it, and the stated range covers the measured number.
By their numbers in this assay, from the lowest: compound 3; then compounds 1 and 4 (each within the scatter of the next).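

Among these compounds, compounds 1 and 4 form the first pair here that differs in one place only, which gives a direct look at a single stereocentre at a saturated chain carbon. In this assay, changing that centre from S to R gives a number 0.30 log units higher from compound 1 to compound 4 (within the scatter), so this pair shows no measurable effect of configuration at this position on the read-out. The comparison is a clean one, with the size of the step judged against how closely repeat readings agree: the fact that compounds 1 and 4 differ only in the configuration as drawn. The agreement of those repeats is seen in: the several entries of compound 2 in this assay, 2.7; 2.8 (2 entries).

The compounds shown leave open whether the second stereo element, which is the same in this pair, would behave in the same way. They also leave open whether configuration at this position would still make so little difference in this assay if a carboxylic acid replaced the alcohol.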